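Replacing methyl with 3-nitrophenyl in compound 3

The compounds below may be only part of what the source reports. "The series", "measured", "known", "first", "only" and "open" are said of these compounds alone.

Compound 1 `c1ccc(COc2ccc(OCCOCCNC3CCCC3)cc2)cc1` gives 24800 nM
Compound 2 `Nc1ccccc1COc1ccc(OCCOCCNC2CCCC2)cc1` gives 14000 nM
Compound 3 `CCOc1ccc(OCCOCCNC2CCCC2)cc1` gives 90500 nM

In a functional assay on SK-OV-3 cells (Homo sapiens) for inhibition, read by CCK-8 assay, with a stated time of 70 h (a lower number here means a stronger inhibitor, a higher number a weaker inhibitor), compound 3 has the highest of the three numbers, 90500 nM. Compound 4 `O=[N+]([O-])c1cccc(COc2ccc(OCCOCCNC3CCCC3)cc2)c1` differs from it by 3-nitrophenyl in place of methyl on a saturated chain carbon bound to an oxygen on an aromatic ring, with 3-nitrophenyl in place of methyl on a saturated chain carbon bound to an oxygen on an aromatic ring. Among the compounds with values here, two measured steps bear on this change when read in reverse: a 3.6-fold higher number from compound 1 to compound 3 (0.56 log units; beyond the scatter) and a 6.5-fold higher number from compound 2 to compound 3 (0.81 log units; beyond the scatter). Both are modest, and in both the methyl compound has the higher number. The step of a 1.8-fold lower number from compound 1 to compound 2 (0.25 log units; within the scatter) stays within the scatter, though 3-nitrophenyl itself remains unmeasured. A similar modest step towards a lower number is therefore expected, namely a 4.5-fold lower number from compound 3 to compound 4 (0.66 log units; beyond the scatter). Compound 4 is estimated at 20000 nM, with an expected range from 8000 nM to 50000 nM.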

Compound 4, half-maximal inhibitory concentration: 15400 nM
Estimate against measurement, compound 4: 1.3-fold (0.11 log units) above; measured number inside the range.
By their numbers in this assay, from the lowest: compounds 2, 4 and 1 (each within the scatter of the next); then compound 3.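

In this assay the step of a 5.9-fold lower number from compound 3 to compound 4 (0.77 log units; beyond the scatter) shows that 3-nitrophenyl on a saturated chain carbon bound to an oxygen on an aromatic ring also improves on methyl, as phenyl and 2-aminophenyl did. Both a 1.6-fold lower number from compound 1 to compound 4 (0.21 log units; within the scatter) and a 1.1-fold higher number from compound 2 to compound 4 (0.04 log units; within the scatter) stay within the scatter, so phenyl, 2-aminophenyl and 3-nitrophenyl cannot be told apart at this position. Nothing measured here gives a reason for these results. Still open, on these data alone, is whether a carboxylic acid or a methoxy on that phenyl ring would also stay within the scatter of compound 1, and whether a longer chain without a ring in place of methyl would match the aromatic groups.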